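Cyanoaziridine ureas: from fluorophenyl to sulfamoylphenyl

The source may hold more compounds than are shown below. What is called first, only, known or untested is meant among the compounds shown, and "the series" means these compounds.

Three ureas built on a cyano-substituted aziridine have been tested in a functional assay on MCF7 cells (Homo sapiens) for inhibition; on this read-out higher numbers stand for weaker inhibition and lower numbers for stronger inhibition. Compound 1 `CCOC(=O)CNC(=O)N1CC1C#N` carries an ethyl ester chain on the urea nitrogen; in this assay compound 1 gives 17000 nM. Compound 3 `CC(C)(C)NC(=O)N1CC1C#N` carries a tert-butyl group instead, and in this assay compound 3 gives 190000 nM. Compound 2 `N#CC1CN1C(=O)Nc1ccc(F)cc1` carries a fluorophenyl group, and in this assay compound 2 gives 2400 nM, the lowest number of the three, with its gaps to compound 1 and to compound 3 both beyond the usual scatter, so compound 2 is the most potent of the measured set.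

The next compound keeps the aromatic ring of compound 2 and exchanges the substituent on it. Compound 4 `N#CC1CN1C(=O)Nc1ccc(S(N)(=O)=O)cc1` differs from compound 2 as follows: sulfamoyl in place of fluoro on an aromatic carbon. Among the compounds with values here, no measured pair shows what such an exchange does on this scaffold, so the step can only be guessed. A modest weakening, close to the edge of the scatter, is expected: the step from compound 2 to compound 4 is estimated at a 2.1-fold higher number from compound 2 to compound 4 (0.32 log units; beyond the scatter). On that basis compound 4 is expected to give about 5000 nM in this assay, in a range from 1200 nM to 25000 nM.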

Compound 4, half-maximal inhibitory concentration: > 15000 nM
Compound 4 gave a limit, no number; the forecaster's own chance of this, stated with the estimate: 10%; middle value at least 3.0-fold (0.47 log units) from the limit.
By their numbers in this assay, from the lowest: compound 2; then compound 1; then compound 3.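

In this assay compound 4 gives a limit rather than a number, > 15000 nM. Even so, the comparison with compound 2 is informative: putting sulfamoyl in place of fluoro on an aromatic carbon gives an at least 6.2-fold higher number from compound 2 to compound 4 (0.79 log units; beyond the scatter), the first evidence that the substituent on this ring can change the read-out by more than the usual scatter, as the earlier compounds differed from each other elsewhere and offered no such comparison. The full size of this step cannot be read, because the value of compound 4 is a limit, so the figure gives only the smallest step consistent with the result: the limit of > 15000 nM in this assay, at which 1 of the 4 values shown sits.

This single pair cannot separate the possible contributions of the change, which replaces one heavy atom with a larger group that also brings a hydrogen-bond donor and hydrogen-bond acceptors. Placing an amine, a carboxylic acid or a methylsulfonyl group on the same aromatic carbon would show whether the weakening is specific to sulfamoyl or extends to other groups, and whether any replacement for fluoro can match or improve on compound 2.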